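The compounds below may be only part of what the source reports. "The series", "measured", "known", "first", "only" and "open" are said of these compounds alone.

Compound 1 `COc1ccc(OCCCCCCN2C[C@H](O)[C@@H](O)[C@H](O)[C@H]2CO)cc1` carries a 4-methoxyphenyl group linked through a chain to the shared core. In an ADME assay on BHK cells (Mesocricetus auratus) for cytotoxicity, read by MTT assay (on this read-out lower numbers stand for higher toxicity in this test and higher numbers for lower toxicity in this test), compound 1 gives > 500000 nM, which is a limit of the test rather than a measured number. Compound 2 `OC[C@@H]1[C@@H](O)[C@H](O)[C@@H](O)CN1CCCCCCOc1ccc(OC(F)(F)F)cc1` likewise gives only a limit, > 500000 nM. Compound 3 `OC[C@@H]1[C@@H](O)[C@H](O)[C@@H](O)CN1CCCCCCOc1cccc(C(F)(F)F)c1` gives 400000 nM. The step that the two limits leave unreadable from compound 1 to compound 2 therefore cannot be sized. Compound 4 `COc1ccccc1OCCCCCCN1C[C@H](O)[C@@H](O)[C@H](O)[C@H]1CO` differs from compound 1 by 2-methoxyphenyl in place of 4-methoxyphenyl on an oxygen on a saturated carbon. Among the compounds with values here, no measured step changes a methoxyphenyl group in this way, so nothing bears directly on it; the only guide is the limit of > 500000 nM in this assay, at which 2 of the 3 values shown sit. The step of a number no higher from compound 1 to compound 4 (the limit leaves the size open) is accordingly expected to stay within the scatter. For compound 4 the estimate in this assay is 500000 nM, within a range from 250000 nM to 1000000 nM.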

Compound 4, half-maximal cytotoxic concentration: > 500000 nM
Compound 4 was reported as a limit; the forecaster's own chance of this, stated with the estimate: 65%; the middle value lies on the limit itself.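

In this assay compound 4 gives > 500000 nM, a limit of the test. Within the data shown here, compound 1 also gives only a limit, so no step from compound 1 to compound 4 can be read. Going by these compounds, how far 2-methoxyphenyl and 4-methoxyphenyl differ here stays open.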